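Fluoro added to the bromophenylsulfonyl arm of compound 2

A few compounds are considered here, and "the series" means these few. Any claim that something is new, unique, unknown or untested is made for them only; others in the source may bear on it.

Working notes on the piperazine pair. Compound 1 `CCN(CC)c1ccc2cc(C(=O)c3ccc(N4CCN(C(=O)COc5ccc(Cl)cc5Cl)CC4)cc3)oc2c1` gives 6170 nM in a functional assay on SGC-7901 cells (Homo sapiens) for cytotoxicity, read by MTT assay, with a stated time of 48 h; a higher number here means a weaker inhibitor, a lower number a stronger inhibitor. Compound 2 `CCN(CC)c1ccc2cc(C(=O)c3ccc(N4CCN(S(=O)(=O)c5ccc(Br)cc5)CC4)cc3)oc2c1` returns in this assay only > 40000 nM, which is a limit and not a number. Going by these compounds, the step of an at least 6.4-fold higher number from compound 1 to compound 2 (0.81 log units; beyond the scatter) sits on that limit; compound 2 stands at the limit of > 40000 nM in this assay, at which 1 of the 2 values shown sits, so its true value is unknown beyond that. Compound 3 `CCN(CC)c1ccc2cc(C(=O)c3ccc(N4CCN(S(=O)(=O)c5ccc(Br)c(F)c5)CC4)cc3)oc2c1` differs from compound 2 by fluoro in place of hydrogen on an aromatic carbon. Within the data shown here, no measured step concerns a change of this kind; the single step in hand, an at least 6.4-fold higher number from compound 1 to compound 2 (0.81 log units; beyond the scatter), exchanges the whole group on the ring nitrogen and is at least modest, which says little about one fluorine on the aromatic ring. For compound 3 the expected step is therefore a step that the limit leaves unreadable from compound 2 to compound 3, none beyond the scatter. Compound 3 is estimated at 50000 nM, within 15000 nM to 160000 nM, and is expected again to yield only a limit.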

Compound 3, half-maximal inhibitory concentration: > 40000 nM
Compound 3: a limit, no number; the forecaster's own chance of this, stated with the estimate: 70%; the middle value lies beyond the limit too.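

In this assay, fluoro on an aromatic carbon of the sulfonyl arm, ortho to a bromo group, still gives no number, and compound 3 joins compound 2 at the limit: the limit of > 40000 nM in this assay, at which 2 of the 3 values shown sit.

Going by these compounds, the step from compound 2 to compound 3 cannot be read, so the size of any change from this fluoro stays unknown. The exchange of the ((2,4-dichlorophenoxy)methyl)carbonyl group for (4-bromo-3-fluorophenyl)sulfonyl gives an at least 6.4-fold higher number from compound 1 to compound 3 (0.81 log units; beyond the scatter), so the gap seen with the 4-bromophenyl arm also holds with fluoro present.

Open, on these data alone, is what a sulfonyl arm would give with an amine or a carboxylic acid in place of the bromo group. Also open, as far as these compounds go, is whether fluoro on the phenoxy ring of compound 1, where a number can be read, would shift that number.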